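A Ring Swap on a Compound That Barely Survives

The compounds below may be only part of what the source reports. "The series", "measured", "known", "first", "only" and "open" are said of these compounds alone.

Compound 1 `O=C(NCc1ccc(S(=O)(=O)N2CCCCC2)cc1)c1cc2ccncc2[nH]1` offers no number to start from. In an ADME assay on microsomes from liver (Mus musculus) for metabolic stability, read by LC-MS, with a stated time of 30 min, tested at 1 uM (a lower number here means that less of the compound is left, a higher number that more of the compound is left), compound 1 gives "below limit of detection" (no number reported). Compound 2 `O=C(NCc1ccc(S(=O)(=O)c2ccccc2)cc1)c1cn2ccnc2cn1` differs from compound 1 in more than one place, and in this assay compound 2 gives 13%.

Compound 3 `O=C(NCc1ccc(S(=O)(=O)N2CCCCC2)cc1)c1ccn2cncc2c1` has the same atoms as compound 1, joined differently. The change, on a carbonyl carbon, is a group of 9 heavy atoms (7 carbon, 2 nitrogen; one five-membered aromatic ring with 2 hetero atoms, one six-membered aromatic ring with 1 hetero atom) in place of a group of 9 heavy atoms (7 carbon, 2 nitrogen; one five-membered aromatic ring with 1 hetero atom, one six-membered aromatic ring with 1 hetero atom), on a carbonyl carbon.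

Among the compounds with values here, no measured pair shows what a swap of this kind does, so any forecast here is loose. Within the data shown here, a small upward step in this assay is expected, perhaps none beyond the usual scatter, and the only numbered guide is compound 2 at 13%. Compound 3 is estimated at 10%, with an expected range from 1% to 30%.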

Compound 3, percent of the compound remaining: 1%
The estimate for compound 3 lay 9 percentage points above the measured number; measured number inside the range.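

In this assay, within the data shown here, compound 1 gives "below limit of detection" (no number reported) and compound 3 gives 1% and no step between the two can be read. No measured evidence bears on this result. The compounds shown leave open whether this ring swap on the carbonyl carbon changes how much compound remains.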